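Furan-to-thiophene swap on a triazole ester series

The source may hold more compounds than are shown below. What is called first, only, known or untested is meant among the compounds shown, and "the series" means these compounds.

Measured so far:
compound 1, `COC(=O)c1nc(-c2ccoc2)n(-c2ccc(F)cc2)n1`, 11700 nM
compound 2, `COC(=O)c1nc(-c2ccsc2)n(-c2ccc(F)cc2)n1`, 10700 nM
compound 3, `COC(=O)c1nc(-c2ccoc2)n(-c2ccc(C(F)(F)F)cc2)n1`, a limit of > 100000 nM

In a functional assay on NPC-TW01 cells (Homo sapiens) for inhibition, read by MTT assay, with a stated time of 72 h (on this read-out lower numbers stand for stronger inhibition of growth and higher numbers for weaker inhibition of growth), compound 1 and compound 2 sit close together. Their change, (thiophen-3-yl in place of furan-3-yl on an aromatic carbon), gives a 1.1-fold lower number from compound 1 to compound 2 (0.04 log units; within the scatter). The change trifluoromethyl in place of fluoro on an aromatic carbon gives an at least 8.5-fold higher number from compound 1 to compound 3 (0.93 log units; beyond the scatter). For compound 3 the value is a limit of the assay and not a number.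

Compound 4, `COC(=O)c1nc(-c2ccsc2)n(-c2ccc(C(F)(F)F)cc2)n1`, is not yet measured. It carries the same kind of change as compound 2, (thiophen-3-yl in place of furan-3-yl on an aromatic carbon); around the place, the neighbouring ring atom bears a large group in place of a 4-fluorophenyl group (7 heavy atoms). Compound 4 is expected to show a step that the limit leaves unreadable from compound 3 to compound 4, resting on the step of a 1.1-fold lower number from compound 1 to compound 2 (0.04 log units; within the scatter). Because compound 3 stands at the limit of > 100000 nM in this assay, at which 1 of the 3 values shown sits, compound 4 is expected to return only a limit as well, with an estimate near 150000 nM.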

Compound 4, concentration for 50% growth inhibition: 34900 nM
For compound 4 the middle estimate is 4.3-fold (0.63 log units) above the measured one, and the stated range ends above it.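

Compound 3 stands at > 100000 nM, which is a limit of the assay and not a number. In this assay, thiophen-3-yl in place of furan-3-yl gives an at least 2.8-fold lower number from compound 3 to compound 4 (0.45 log units; beyond the scatter), so the change carries over to the trifluoromethyl compounds without a loss, but equal size on the two cores is not shown: the same change on two cores in this assay, a 1.1-fold lower number (0.04 log units; within the scatter) from compound 1 to compound 2 and an at least 2.8-fold lower number (0.45 log units; beyond the scatter) from compound 3 to compound 4; the limit leaves it open whether they differ Trifluoromethyl in place of fluoro gives a 3.3-fold higher number from compound 2 to compound 4 (0.51 log units; beyond the scatter), so the number rises on both cores, and the size comparison again stays unsettled: the same change on two cores in this assay, an at least 8.5-fold higher number (0.93 log units; beyond the scatter) from compound 1 to compound 3 and a 3.3-fold higher number (0.51 log units; beyond the scatter) from compound 2 to compound 4; the limit leaves it open whether they differ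

Still open, as far as these compounds go, is how the thiophen-3-yl change reads with a carboxylic acid or an amide in place of the methoxycarbonyl group. Also open, from the compounds shown here alone, is how it reads with chloro or methoxy in place of fluoro on the phenyl ring.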